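The compounds below may be only part of what the source reports. "The series", "measured", "known", "first", "only" and "open" are said of these compounds alone.

Measured so far:
- compound 1, `COC(=O)C[C@H](NC(=O)Nc1ccc(N(C)Cc2cnc3nc(N)nc(N)c3n2)cc1)C(=O)OC`, gives 3.9 ug/mL in a functional assay on CCRF-CEM cells (Homo sapiens) for inhibition; on this read-out higher numbers stand for weaker inhibition and lower numbers for stronger inhibition
- compound 2, `COC(=O)CC[C@H](NC(=O)Nc1ccc(N(C)Cc2cnc3nc(N)nc(N)c3n2)cc1)C(=O)OC`, gives 3.5 ug/mL

For the measured compounds named here, compound 2 holds the lowest of the two numbers, yet its only neighbour, compound 1, lies within the scatter: a 1.1-fold lower number from compound 1 to compound 2 (0.05 log units; within the scatter). Compound 3, `CN(Cc1cnc2nc(N)nc(N)c2n1)c1ccc(NC(=O)NC(CC(=O)O)C(=O)O)cc1`, has not been measured. Its change from compound 2 is 1,2-dicarboxyethyl in place of 1,3-bis(methoxycarbonyl)propyl on an amide-type nitrogen. Going by the values given here, neither measured step covers a swap of esters for acids; the single step known concerns chain length only. No direction can therefore be expected with confidence, and the range must be wide. Compound 3 is estimated at 6 ug/mL (range 1.2 ug/mL to 40 ug/mL), a step of a 1.7-fold higher number from compound 2 to compound 3 (0.23 log units; within the scatter).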

Compound 3, concentration for 50% inhibition: 3.2 ug/mL
For compound 3 the middle estimate is 1.9-fold (0.27 log units) above the measured one; low and high end bracket the measured number.
By their numbers in this assay, from the lowest: compounds 3, 2 and 1 (each within the scatter of the next).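

Replacing 1,2-bis(methoxycarbonyl)ethyl with 1,2-dicarboxyethyl on the amide-type nitrogen compares free acids with methyl esters on the same chain, and in this assay this gives a 1.2-fold lower number from compound 1 to compound 3 (0.09 log units; within the scatter). The change that also shortens the chain gives a 1.1-fold lower number from compound 2 to compound 3 (0.04 log units; within the scatter), so neither change separates these compounds at this position. No information is available that would explain this result.

Still open, as far as these compounds go, is whether a longer chain carrying two carboxylic acids, or an amine in place of the acids, would shift the number beyond the scatter.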